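This account rests on a few compounds, and the source may have more. Where it says the series, first, only, none or still open, it means among the compounds named here.

Compound 1 `C=C[C@@](C)(/C=C/c1ccc(Nc2ccc(Cl)cc2)cc1)CCC=C(C)C`: > 36600 nM
Compound 2 `C=C[C@@](C)(/C=C/c1ccc(-c2cccc(F)c2)cc1)CCC=C(C)C`: > 36600 nM

In an ADME assay on BJ cells (Homo sapiens) for cytotoxicity, with a stated time of 72 h (a lower number here means that less compound is needed, a higher number that more compound is needed for the effect), compound 2 gives > 36600 nM, which is a limit and not a number. Compound 1 gives > 36600 nM, which is likewise a limit. All that is known so far is the limit of > 36600 nM in this assay, at which 2 of the 2 values shown sit.

Compound 3 `C=C[C@@](C)(/C=C/c1ccc(-c2ccc(Cl)c(Cl)c2)cc1)CCC=C(C)C` carries 3,4-dichlorophenyl in place of the 3-fluorophenyl of compound 2, on an aromatic carbon para to a large group: 3,4-dichlorophenyl in place of 3-fluorophenyl on an aromatic carbon. For the measured compounds named here, the only measured step that bears on this change is a step that the two limits leave unreadable from compound 1 to compound 2. Going by the values given here, it offers no size to carry over, so no step of a definite size or direction is expected in this assay. The expected step is a step that the limit leaves unreadable from compound 2 to compound 3. For compound 3 the estimated value is 40000 nM. The expected range for compound 3 runs from 15000 nM to 100000 nM.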

Compound 3, half-maximal effective concentration: > 36600 nM
Compound 3 was reported as a limit (the forecaster's own chance of this, stated with the estimate: 80%); the middle value is on the limit's open side.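

Compound 3 is reported as a limit, as are compound 1 and compound 2, so no step among these three compounds can be read in this assay: the limit of > 36600 nM in this assay, at which 3 of the 3 values shown sit.

The compounds shown leave open whether any of these changes on the shared core alters the read-out, and at what concentration each compound would reach its half-maximal effect.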